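Hydroxyphenyl placement on the shared core

The source may report more compounds than this note shows. Statements on the series, on what has been measured and on what is new or still open speak of the compounds shown alone.

Compound 1 `Oc1ccc(-c2cc(-c3ccc(F)cc3)cc(-c3ccccc3O)n2)cc1`: in a functional assay on DU-145 cells (Homo sapiens) for inhibition (on this read-out higher numbers stand for weaker inhibition and lower numbers for stronger inhibition), compound 1 gives > 50000 nM, which is a limit of the assay.
Compound 2 `Oc1ccc(-c2cc(-c3ccccc3C(F)(F)F)cc(-c3ccccc3O)n2)cc1`: in this assay compound 2 gives 6690 nM.
Compound 3 `Oc1ccc(-c2cc(-c3cccc(C(F)(F)F)c3)cc(-c3ccccc3O)n2)cc1`: in this assay compound 3 gives > 50000 nM, again a limit of the assay.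

Compound 3 therefore stands at the limit, sharing it with compound 1 (the limit of > 50000 nM in this assay, at which 2 of the 3 values shown sit). Among the compounds with values here, compound 2 is the only compound with a number; the measured steps are an at least 7.4-fold lower number from compound 1 to compound 2 (0.87 log units; beyond the scatter) and an at least 7.4-fold higher number from compound 2 to compound 3 (0.87 log units; beyond the scatter), while a step that the two limits leave unreadable from compound 1 to compound 3.

Compound 4 `Oc1ccc(-c2cc(-c3cccc(C(F)(F)F)c3)cc(-c3ccc(O)cc3)n2)cc1` differs from compound 3 by 4-hydroxyphenyl in place of 2-hydroxyphenyl on an aromatic carbon. Within the data shown here, none of the measured steps touches a hydroxyphenyl group; each moves the fluorophenyl or trifluoromethylphenyl, so they give no direct reading on this change. With compound 3 at a limit, compound 4 is expected to stay near it, a number no higher from compound 3 to compound 4 (the limit leaves the size open). The estimate for compound 4 is 50000 nM, in the range 10000 nM to 200000 nM.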

Compound 4, half-maximal inhibitory concentration: > 50000 nM
Compound 4: no number, only a limit; the forecaster's own chance of this, stated with the estimate: 70%; the middle value lies on the limit itself.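

Compound 3 and compound 4 both stand at a limit of this assay, not at a number, so the step between them cannot be read: the limit of > 50000 nM in this assay, at which 3 of the 4 values shown sit.

Still open, on these data alone, is whether 4-hydroxyphenyl in place of 2-hydroxyphenyl changes inhibition on a compound with a measurable number, such as compound 2.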